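A few compounds are considered here, and "the series" means these few. Any claim that something is new, unique, unknown or untested is made for them only; others in the source may bear on it.

In a functional assay on A549 cells (Homo sapiens) for inhibition, read by CCK-8 assay, with a stated time of 72 h, tested at 2 uM (on this read-out higher numbers stand for more inhibition of growth at the one concentration tested and lower numbers for less inhibition of growth), compound 1 `Cc1cc(C)cc(SCc2ccc(/C=C/C(=O)Nc3ccccc3N)cc2)c1` gives 46.1%, compound 2 `Nc1ccccc1NC(=O)/C=C/c1ccc(CSc2ccc(Cl)cc2)cc1` gives 55.3% and compound 3 `Nc1ccccc1NC(=O)/C=C/c1ccc(CSc2ccc(C(F)(F)F)cn2)cc1` gives 51.7%. Compound 3 therefore stands within the scatter of both other compounds, with a number 5.6 percentage points higher from compound 1 to compound 3 (within the scatter) and a number 3.6 percentage points lower from compound 2 to compound 3 (within the scatter). Compound 4 `Nc1ccccc1NC(=O)/C=C/c1ccc(CSCCc2ccccc2)cc1` changes the group on the sulfur: phenethyl in place of 5-(trifluoromethyl)pyridin-2-yl on a sulfur. Among the measured compounds shown here, no measured compound carries phenethyl there, so the measured steps bear on this change only indirectly. They are aromatic replacements at the same place, and even the widest, a number 9.2 percentage points higher from compound 1 to compound 2 (within the scatter), stays within the scatter. On that basis, the expected change in this assay is none beyond the scatter, and the expected step is a number 2.7 percentage points lower from compound 3 to compound 4 (within the scatter). The estimate for compound 4 is 49%, with an expected range of 36% to 60%.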

Compound 4, percent growth inhibition at one concentration: 45.7%
Compound 4: middle estimate off by 3.3 percentage points, on the high side, within the range that was stated.
By their numbers in this assay, from the lowest: compounds 4, 1, 3 and 2 (each within the scatter of the next).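

In this assay the sulfur also carries phenethyl, an aromatic ring held on a chain, and the number stays within the scatter of all three aromatic groups, with a number 6 percentage points lower from compound 3 to compound 4 (within the scatter) and a number 9.6 percentage points lower from compound 2 to compound 4 (within the scatter) and also a number 0.4 percentage points lower from compound 1 to compound 4 (within the scatter) in this set. At this single concentration, the series therefore does not separate a chain-borne ring from a ring on the sulfur itself. Nothing available explains these numbers. As far as these compounds go, whether an amine, a carboxylic acid or a longer chain on the sulfur would give a step beyond the scatter stays open.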